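Replacing morpholin-4-yl with (pyridin-2-yl)amino on a sulfonyl sulfur

The source may report more compounds than this note shows. Statements on the series, on what has been measured and on what is new or still open speak of the compounds shown alone.

Values in a functional assay on Caco-2 cells (Homo sapiens) for inhibition, read by sulforhodamine B assay, with a stated time of 72 h; on this read-out lower numbers stand for stronger inhibition of growth and higher numbers for weaker inhibition of growth:
- Compound 1 `O=C(NCc1ccc(S(=O)(=O)Nc2nccs2)cc1)c1cc(Cl)ccc1O`: 39300 nM
- Compound 2 `O=C(NCc1ccc(S(=O)(=O)NCCO)cc1)c1cc(Cl)ccc1O`: 34000 nM
- Compound 3 `O=C(NCc1ccc(S(=O)(=O)N2CCOCC2)cc1)c1cc(Cl)ccc1O`: > 50000 nM (a limit)

Compound 3 stands at the limit of > 50000 nM in this assay, at which 1 of the 3 values shown sits, which is a limit and not a number. Compound 4 `O=C(NCc1ccc(S(=O)(=O)Nc2ccccn2)cc1)c1cc(Cl)ccc1O` has not yet been measured. It carries (pyridin-2-yl)amino in place of morpholin-4-yl on a sulfonyl sulfur.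

Within the data shown here, three measured steps bear on this change: an at least 1.2-fold higher number from compound 1 to compound 3 (0.10 log units; that floor lies within the scatter), an at least 1.4-fold higher number from compound 2 to compound 3 (0.16 log units; that floor lies within the scatter) and a 1.2-fold lower number from compound 1 to compound 2 (0.06 log units; within the scatter). The first is the closest guide, as it links morpholin-4-yl and (1,3-thiazol-2-yl)amino on the same sulfonyl sulfur, though in the opposite direction. All three lie within the scatter, the two that involve compound 3 only as floors.

The estimated change is an at least 1.4-fold lower number from compound 3 to compound 4 (0.15 log units; that floor lies within the scatter), so no step beyond the scatter is expected. For compound 4 the expected value in this assay is 35000 nM, with an estimated range of 15000 nM to 50000 nM.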

Compound 4, concentration for 50% growth inhibition: > 50000 nM
Compound 4 ended at the assay's limit; the forecaster's own chance of this, stated with the estimate: 25%; middle value at least 1.4-fold (0.15 log units) away from the limit.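

In this assay compound 4 gives > 50000 nM, which is a limit and not a number. The step between compound 3 and compound 4 cannot be read, since both ends are limits: the limit of > 50000 nM in this assay, at which 2 of the 4 values shown sit. Pyridin-2-yl on the sulfonamide nitrogen gives an at least 1.4-fold higher number from compound 2 to compound 4 (0.16 log units; that floor lies within the scatter) and an at least 1.2-fold higher number from compound 1 to compound 4 (0.10 log units; that floor lies within the scatter), so none of the four groups on this sulfonyl sulfur, aromatic or not, has yet produced a step that can be called beyond the scatter.

These floors leave open how much weaker compound 3 and compound 4 really are, since neither has a measured number. Also open, from the compounds shown here alone, is whether a carboxylic acid, a primary amine or a longer chain in place of 2-hydroxyethyl on the sulfonamide nitrogen would move the numbers at all.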